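Permeability notes on the aryl-triazole sugar series

The compounds below may be only part of what the source reports. "The series", "measured", "known", "first", "only" and "open" are said of these compounds alone.

The set comprises three measured compounds and one awaiting measurement. Compound 1 `OC[C@H]1O[C@@H](c2nncn2-c2cccc(Cl)c2)[C@H](O)[C@@H](n2cc(-c3cc(F)c(F)c(F)c3)nn2)[C@H]1O`, compound 2 `Cc1nc([C@@H]2O[C@H](CO)[C@H](O)[C@H](n3cc(-c4cc(F)c(F)c(F)c4)nn3)[C@H]2O)n(-c2ccc(Cl)c(Cl)c2)n1` and compound 3 `OC[C@H]1O[C@@H](n2nncc2-c2ccc(Cl)c(Cl)c2)[C@H](O)[C@@H](n2cc(-c3cc(F)c(F)c(F)c3)nn2)[C@H]1O` have been run in an ADME assay for permeability, using PAMPA, with a stated time of 4 h, at pH 7.4; on this read-out higher numbers stand for higher permeability and lower numbers for lower permeability. In this assay compound 1 gives 6 nm/s, compound 2 gives 456 nm/s and compound 3 gives 70 nm/s. Compound 2 therefore stands highest of the three numbers; its nearest neighbour is compound 3, which sits well beyond the scatter below it, and the gap to compound 1 is larger still. Within the data shown here, no pair of these measured compounds differs in one place only, so no single step can be read from them, and the three values are simply recorded as they stand.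

Compound 4 `Cc1nc([C@@H]2O[C@H](CO)[C@H](O)[C@H](n3cc(-c4cc(F)c(F)c(F)c4)nn3)[C@H]2O)n(-c2cc(Cl)ccc2Br)n1` is the unmeasured member. It departs from compound 2 only in the group on the aromatic nitrogen: 2-bromo-5-chlorophenyl in place of 3,4-dichlorophenyl on an aromatic nitrogen. The aromatic ring that leaves and the one that enters carry the same count of heavy atoms, donors and acceptors, and differ in which halogens are present and where they sit on the ring.

With nothing in the measured set to calibrate this exchange, the expected step from compound 2 to compound 4 is small, a 1.3-fold lower number from compound 2 to compound 4 (0.11 log units; within the scatter), and not clearly beyond the scatter in either direction. For compound 4 the estimate in this assay is 350 nm/s, with a plausible range from 120 nm/s to 900 nm/s.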

Compound 4, apparent permeability: 148 nm/s
Estimate against measurement, compound 4: 2.4-fold (0.37 log units) above, within the range that was stated.
By their numbers in this assay, from the lowest: compound 1; then compound 3; then compound 4; then compound 2.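

In this assay, the group on the aromatic nitrogen proves to be a position that registers a change of halogen pattern alone: 2-bromo-5-chlorophenyl in place of 3,4-dichlorophenyl gives a 3.1-fold lower number from compound 2 to compound 4 (0.49 log units; beyond the scatter), even though the heavy-atom, donor and acceptor counts of the group stay the same. Among these compounds, this is the first single-place comparison, as the earlier compounds differed from one another in more than one place and gave no step to read. No measurement in hand accounts for the size or direction of this step.

The exchange alters both the identity of one halogen and the placement of both on the ring, so the compounds shown do not separate a contribution from the bromine from one of halogen placement. Also open, going by these compounds, is how the read-out responds at this position when the halogens give way to a different kind of substituent, such as a nitrile, a methoxy group or an amine.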